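This account rests on a few compounds, and the source may have more. Where it says the series, first, only, none or still open, it means among the compounds named here.

Values in a functional assay on K562 cells (Homo sapiens) for antiproliferative activity, read by MTT assay, with a stated time of 72 h (a lower number here means a stronger inhibitor, a higher number a weaker inhibitor), are these:
- compound 1 `COc1cc(-n2ncnc2-c2ccc(OC(F)(F)F)cc2)cc(OC)c1OC` has the limit > 10000 nM as its result
- compound 2 `COc1cc(-n2ncnc2-c2ccc(OC(C)C)cc2)cc(OC)c1OC` has 800 nM as its value
- compound 3 `COc1cc(-n2ncnc2-c2cccc(Cl)c2)cc(OC)c1OC` has the limit > 10000 nM as its result

Compound 3 has no number, only a limit (the limit of > 10000 nM in this assay, at which 2 of the 3 values shown sit). Compound 4 `COc1cc(-n2ncnc2-c2ccc(F)cc2)cc(OC)c1OC` carries 4-fluorophenyl in place of 3-chlorophenyl on an aromatic carbon. Among the compounds with values here, the one measured step (an at least 12-fold lower number from compound 1 to compound 2 (1.09 log units; beyond the scatter)) is large, but it swaps a different group, so it shows only that a change on the shared core can matter in this assay and gives no size for this one. No step beyond the scatter is therefore expected (an at least 1.1-fold lower number from compound 3 to compound 4 (0.04 log units; that floor lies within the scatter)). Compound 4 is estimated at 9000 nM (expected range 2000 nM to 30000 nM).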

Compound 4, half-maximal inhibitory concentration: > 10000 nM
Compound 4 ended at the assay's limit; the forecaster's own chance of this, stated with the estimate: 60%; at least 1.1-fold (0.04 log units) between middle value and limit.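

In this assay, fluoro in place of isopropoxy on an aromatic carbon gives an at least 12-fold higher number from compound 2 to compound 4 (1.09 log units; beyond the scatter). Of the three groups compared at this place, trifluoromethoxy, fluoro and isopropoxy, only isopropoxy gives a number rather than a limit. The steps to compound 4 from compound 1 and from compound 3 cannot be read, because both ends of each are limits: the limit of > 10000 nM in this assay, at which 3 of the 4 values shown sit.

Going by these compounds, whether an amine, a carboxylic acid or a longer chain such as butoxy at this place would also give a number stays open. On these data alone, how compound 1, compound 3 and compound 4 rank among themselves also stays open.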